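This account rests on a few compounds, and the source may have more. Where it says the series, first, only, none or still open, it means among the compounds named here.

Measured compounds:
- Compound 1, `O=c1c2ccccc2c(-c2cccnc2)nn1Cc1ccccc1`: 97%
- Compound 2, `O=c1c2ccccc2c(-c2cccnc2)nn1Cc1cccc(Cl)c1`: 95%
- Compound 3, `CC(=O)OCCn1nc(-c2cccnc2)c2ccccc2c1=O`: 32%

These three share one core and differ only in the group attached at the saturated chain carbon bound to an aromatic nitrogen. In an assay on isolated protein (Oryctolagus cuniculus) with Thromboxane-A synthase (Homo sapiens) as the target, tested at 1 uM (a higher number here means more inhibition at the concentration tested (going by the name of the read-out), a lower number less inhibition), compound 3 stands lowest of the three. The step of a number 65 percentage points lower from compound 1 to compound 3 (beyond the scatter) and the step of a number 63 percentage points lower from compound 2 to compound 3 (beyond the scatter) both show that replacing a phenyl or 3-chlorophenyl group there with acetoxymethyl cuts the inhibition sharply, while the step of a number 2 percentage points lower from compound 1 to compound 2 (within the scatter) shows that a chloro on the aromatic ring changes little.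

Compound 4, `CCOC(=O)Cn1nc(-c2cccnc2)c2ccccc2c1=O`, is not yet measured. It differs from compound 3 by ethoxycarbonyl in place of acetoxymethyl on a saturated chain carbon bound to an aromatic nitrogen. The same atoms are present but joined differently, so the chain stays short and the aryl group that goes with high inhibition in compounds 1 and 2 is still absent. Among the measured compounds shown here, no measured step compares two such short chains with each other, so the direction of any change is unknown; the two large drops into compound 3 only suggest that a short chain of this kind gives low inhibition.

For compound 4 the expected step in this assay is a number 2 percentage points lower from compound 3 to compound 4 (within the scatter), that is, no change beyond the scatter. Compound 4 is therefore estimated at 30%, within a range from 10% to 55%.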

Compound 4, a percentage reported as inhibition, at one concentration (the size of the read-out at that concentration, not a potency): 28%
Compound 4: the middle estimate sits 2 percentage points above what was measured; the measured number falls inside the stated range.
By their numbers in this assay, from the lowest: compounds 4 and 3 (each within the scatter of the next); then compounds 2 and 1 (each within the scatter of the next).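

Swapping acetoxymethyl for ethoxycarbonyl at this position, on a saturated chain carbon bound to an aromatic nitrogen, gives a number 4 percentage points lower from compound 3 to compound 4 (within the scatter) in this assay, so rearranging the same atoms within this short chain makes no difference that can be told from the scatter. The comparisons with the phenyl and 3-chlorophenyl groups give a number 67 percentage points lower from compound 2 to compound 4 (beyond the scatter) and a number 69 percentage points lower from compound 1 to compound 4 (beyond the scatter), so the large loss seen earlier is not peculiar to acetoxymethyl but appears with both chains shown that carry no aromatic ring. Nothing measured here explains these drops or bears on why the two short chains read alike.

On these data alone, what remains open is whether the aromatic ring itself is needed or whether the ester groups in compound 3 and compound 4 are what go with the low numbers, a question that a plain butyl chain, with no ester in it, could help to settle. As far as these compounds go, it is also open how this position would respond to a carboxylic acid in place of the ethyl ester, to an amine at the end of the chain, or to a longer chain ending in phenyl, such as 2-phenylethyl.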